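The compounds below may be only part of what the source reports. "The series", "measured", "known", "first", "only" and "open" are said of these compounds alone.

Compound 1 `COc1ccc(OC)c(N2CCN(CCCCN3C(=O)c4ccccc4C3=O)CC2)c1` carries a 2,5-dimethoxyphenyl group on an amine nitrogen in a ring of its core. Among the measured compounds shown here, in an assay on frontal cortex for binding affinity to Adrenergic receptor alpha-1 (Rattus norvegicus), read by radioligand binding (on this read-out lower numbers stand for stronger inhibition and higher numbers for weaker inhibition), compound 1 gives 15 nM, the smallest of the three numbers so far, though not separated from all of them: compound 3 `O=C1c2ccccc2C(=O)N1CCCCN1CCN(c2cccc3ccccc23)CC1`, which bears a naphthalen-1-yl group in the same place, gives 22 nM in this assay, and the step of a 1.5-fold higher number from compound 1 to compound 3 (0.17 log units; within the scatter) stays within the scatter. Compound 2 `O=C1c2ccccc2C(=O)N1CCCCN1CCN(c2ccc([N+](=O)[O-])cc2)CC1`, with a 4-nitrophenyl group there, gives 378 nM in this assay, a step of a 25-fold higher number from compound 1 to compound 2 (1.40 log units; beyond the scatter); the return step a 17-fold lower number from compound 2 to compound 3 (1.24 log units; beyond the scatter) is of the same order.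

Compound 4 `CC(=O)Nc1ccc(N2CCN(CCCCN3C(=O)c4ccccc4C3=O)CC2)cc1` has not yet been measured in this assay. Its difference from compound 1 is 4-acetamidophenyl in place of 2,5-dimethoxyphenyl on an amine nitrogen in a ring. For the measured compounds named here, the step bearing most on it is the one from compound 1 to compound 2, where the two methoxy groups likewise gave way to a single group on a six-membered aromatic ring of carbon only, and the number rose by a large margin. A rise of similar direction but smaller size is expected here, with the step of a 10-fold higher number from compound 1 to compound 4 (1.00 log units; beyond the scatter). Compound 4 is therefore estimated at 150 nM, within a range from 40 nM to 600 nM.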

Compound 4, inhibition constant: < 1000 nM
Compound 4: only a limit was reported; the forecaster's own chance of this, stated with the estimate: 3%; the middle value lies beyond the limit too.
By their numbers in this assay, from the lowest: compounds 1 and 3 (each within the scatter of the next); then compound 2.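

For compound 4 only a limit was reported, not a number: the limit of < 1000 nM in this assay, at which 1 of the 4 values shown sits. Among the compounds shown here, no step from compound 1, compound 2 or compound 3 to compound 4 can be read. The compounds shown leave open where compound 4 stands among these three, and so how 4-acetamidophenyl compares with the other groups on the amine nitrogen in a ring.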